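The compounds below may be only part of what the source reports. "The series", "measured", "known", "first", "only" and "open" are said of these compounds alone.

Measured so far in a functional assay for activation of retinoic acid receptor alpha (Homo sapiens); a lower number here means a smaller maximal response, a higher number a larger maximal response:
- compound 1 `C/C(=C\c1ccc(C(=O)c2ccc3c(c2)C(C)(C)CCC3(C)C)cc1)C(=O)O`: 37%
- compound 2 `CC1(C)CCC(C)(C)c2cc(C(=O)c3ccc(C#CC(=O)O)cc3)ccc21`: 0%

Compound 2 holds the lowest value of the two; its nearest neighbour is compound 1, which in this assay gives 37%, while compound 2 gives 0%. Among the measured compounds shown here, the only measured step is a number 37 percentage points lower from compound 1 to compound 2 (beyond the scatter), a change confined to the acid-bearing side chain on the shared core.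

Compound 3 `CC1(C)CCC(C)(C)c2cc(C(=O)c3ccc(/C=C\C(=O)O)cc3)ccc21` is not yet measured. Its change from compound 2 is 2-carboxyethenyl in place of 2-carboxyethynyl on an aromatic carbon. The change again touches only that side chain, so the step from compound 1 to compound 2 is the one that bears on it. That step was large and downward on exchanging the side chain of compound 1 for 2-carboxyethynyl. Compound 3 does not restore the side chain of compound 1, but it moves away from the group that gave no response. A partial return toward the value of compound 1 is expected, though the absence of any measured 2-carboxyethenyl analogue leaves the size open; the expected step is a number 10 percentage points higher from compound 2 to compound 3 (within the scatter). For compound 3 the maximal response in this assay is estimated at 10%, with a range from 0% to 30%.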

Compound 3, largest response reached (reported as maximum), in percent of the reference or control that the assay uses: 0%
Compound 3: the middle estimate sits 10 percentage points above what was measured, and the stated range covers the measured number.
By their numbers in this assay, from the lowest: compounds 2 and 3 (each within the scatter of the next); then compound 1.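

In this assay, putting 2-carboxyethenyl in place of 2-carboxyethynyl on this aromatic carbon, para to a large group, gives no change at the digits printed from compound 2 to compound 3 (within the scatter), so replacing the triple bond with a double bond does not bring back a response at this position. The chain of compound 1 and that of compound 3 both hold a double bond, yet the exchange of 2-carboxyprop-1-en-1-yl for 2-carboxyethenyl gives a number 37 percentage points lower from compound 1 to compound 3 (beyond the scatter), which shows that a double bond in the acid-bearing chain is not enough for a response and that, among these three compounds, only the 2-carboxyprop-1-en-1-yl chain gives one. No measurement at hand accounts for this difference between the chains.

Still open, from the compounds shown here alone, is whether the response of compound 1 depends on the extra methyl of its chain as such, or whether an ethyl group at that carbon of the chain, or a saturated 2-carboxyethyl chain, would also give one. The compounds shown also leave open how the response changes if the carboxylic acid is replaced by a tetrazole on the same shared core.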